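The source may hold more compounds than are shown below. What is called first, only, known or untested is meant among the compounds shown, and "the series" means these compounds.

In an ADME assay on microsomes from liver (Mus musculus) for metabolic stability, with a stated time of 10 min (a lower number here means that less of the compound is left, a higher number that more of the compound is left), compound 1 (`COC[C@]1(C(=O)N2CC[C@](c3ccc(C(F)(C(F)(F)F)C(F)(F)F)cc3)(S(=O)(=O)c3ccc(F)cc3)C2)CC[C@H](C(=O)O)CC1`) gives 88% and compound 2 (`O=C(O)C12CCC(C(=O)N3CC[C@](c4ccc(C(F)(C(F)(F)F)C(F)(F)F)cc4)(S(=O)(=O)c4ccc(F)cc4)C3)(CC1)OC2`) gives 94% on the same core, so compound 2 stands level with compound 1 within the scatter. Both numbers show that most of the compound is left. Going on to compound 3 (`O=C([C@H]1CC[C@H](c2nnn[nH]2)CC1)N1CC[C@](c2ccc(C(F)(C(F)(F)F)C(F)(F)F)cc2)(S(=O)(=O)c2ccc(F)cc2)C1`), the core stays and the change is a group of 11 heavy atoms (7 carbon, 4 nitrogen; one five-membered aromatic ring with 4 hetero atoms, one six-membered non-aromatic ring of carbon only) in place of a group of 11 heavy atoms (8 carbon, 3 oxygen; one six-membered non-aromatic ring of carbon only, one six-membered non-aromatic ring with 1 hetero atom), on a carbonyl carbon with the entering group named 4-(1H-tetrazol-5-yl)cyclohexyl. For the measured compounds named here, the one measured step at this place is a number 6 percentage points higher from compound 1 to compound 2 (within the scatter) and it is the only guide. Going by the values given here, no measured compound carries the five-membered aromatic ring with 4 hetero atoms, so the evidence is thin. A step beyond the scatter is therefore not expected in this assay on what is known so far. The expected step is a number 6 percentage points lower from compound 2 to compound 3 (within the scatter) on this reasoning. For compound 3 the estimated value is 88% with an expected range from 70% to 98% for repeat measurements.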

Compound 3, percent of the compound remaining: 73%
Compound 3: middle estimate off by 15 percentage points, on the high side; measured number inside the range.
By their numbers in this assay, from the lowest: compound 3; then compounds 1 and 2 (each within the scatter of the next).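

In this assay, this place on the carbonyl carbon turns out not to accept every group equally: the earlier swap here stayed within the scatter, whereas 4-(1H-tetrazol-5-yl)cyclohexyl gives a number 21 percentage points lower from compound 2 to compound 3 (beyond the scatter) and also a number 15 percentage points lower from compound 1 to compound 3 (beyond the scatter). So a change at this place can move the amount of compound left beyond the usual scatter, even though the entering and leaving groups in the step from compound 2 are the same size in heavy atoms. Nothing measured here explains the fall.

The compounds shown leave open whether the tetrazole ring itself accounts for the lower number, or the other differences in the group do, since the ring oxygen and the methoxymethyl chain leave as well. A plain 4-carboxycyclohexyl group at this place would help separate these, as would the same tetrazole on a longer chain.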